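A few compounds are considered here, and "the series" means these few. Any claim that something is new, unique, unknown or untested is made for them only; others in the source may bear on it.

Compound 1 `Nc1ccccc1NC(=O)c1ccc(CSC(=S)N2CCN(c3ccc(Cl)cc3)CC2)cc1`: 51.2%
Compound 2 `Nc1ccccc1NC(=O)c1ccc(CSC(=S)N2CCN(c3cccnc3)CC2)cc1`: 66.2%

In a functional assay on HeLa cells (Homo sapiens) for antiproliferative activity, read by CCK-8 assay, with a stated time of 72 h, tested at 2 uM (a lower number here means a weaker effect, a higher number a stronger effect of the compound at the concentration tested), compound 2 gives 66.2%, the higher of the two values, with compound 1 at 51.2%. Compound 3 `N#Cc1ccc(N2CCN(C(=S)SCc3ccc(C(=O)Nc4ccccc4N)cc3)CC2)cc1` carries a change at the same ring nitrogen, (4-cyanophenyl in place of pyridin-3-yl on an amine nitrogen in a ring). Within the data shown here, the only step bearing on it is a number 15 percentage points higher from compound 1 to compound 2 (beyond the scatter), which swapped one aryl group for another at this position. A 4-cyanophenyl group, like 4-chlorophenyl, is a carbon-only ring, so a move back toward the value of compound 1 seems likelier than a further rise. Compound 3 is therefore expected to give about 56%, from 40% to 72%. That estimate means an expected step of a number 10.2 percentage points lower from compound 2 to compound 3 (beyond the scatter).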

Compound 3, a percentage reported as inhibition, at one concentration (the size of the read-out at that concentration, not a potency): 71.6%
The estimate for compound 3 lay 15.6 percentage points below the measured number; the range from low to high includes it.
By their numbers in this assay, from the lowest: compound 1; then compounds 2 and 3 (each within the scatter of the next).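

In this assay, a carbon-only ring at this ring nitrogen does not by itself lower the read-out: 4-cyanophenyl in place of pyridin-3-yl gives a number 5.4 percentage points higher from compound 2 to compound 3 (within the scatter) and leaves the two groups indistinguishable. What the carbon-only ring carries does matter here, as cyano in place of chloro gives a number 20.4 percentage points higher from compound 1 to compound 3 (beyond the scatter) on an otherwise unchanged compound. No evidence is available to explain this difference. The compounds shown leave open how a methoxy group or an amine on the same ring would compare, and whether a saturated ring such as cyclohexyl could replace the aromatic ring at this nitrogen.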